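A second fluoro on the aryl ring of compound 3

This account rests on a few compounds, and the source may have more. Where it says the series, first, only, none or still open, it means among the compounds named here.

Three compounds share one core and differ only in the aryl hydrazone group. In an ADME assay on HT-29 cells (Homo sapiens) for inhibition, read by MTT assay, with a stated time of 72 h (on this read-out lower numbers stand for stronger inhibition and higher numbers for weaker inhibition), compound 1 `CN(C)C/C=C/C(=O)Nc1cccc(Nc2nc(N/N=C/c3ccccc3F)ncc2Cl)c1` gives 3660 nM, compound 2 `COc1ccc(/C=N/Nc2ncc(Cl)c(Nc3cccc(NC(=O)/C=C/CN(C)C)c3)n2)cc1` gives 4820 nM, and compound 3 `C/C(=N\Nc1ncc(Cl)c(Nc2cccc(NC(=O)/C=C/CN(C)C)c2)n1)c1ccc(F)cc1` gives 10200 nM, the highest of the three numbers. The steps run a 1.3-fold higher number from compound 1 to compound 2 (0.12 log units; within the scatter), a 2.8-fold higher number from compound 1 to compound 3 (0.45 log units; beyond the scatter) and a 2.1-fold higher number from compound 2 to compound 3 (0.33 log units; beyond the scatter), so swapping whole aryl groups moved the read-out only modestly. Compound 4 `C/C(=N\Nc1ncc(Cl)c(Nc2cccc(NC(=O)/C=C/CN(C)C)c2)n1)c1ccc(F)cc1F` differs from compound 3 by fluoro in place of hydrogen on an aromatic carbon, ortho to a large group and meta to a fluoro group; seen one bond further out, 4-fluorophenyl becomes 2,4-difluorophenyl. Among the measured compounds shown here, no measured step adds a single fluoro to an otherwise unchanged ring, so none bears on this change directly; the exchanges among compounds 1, 2 and 3 show only that changes on this ring shift the number by modest amounts in either direction. The author therefore expects no step beyond the scatter, a 1.0-fold lower number from compound 3 to compound 4 (0.01 log units; within the scatter). For compound 4 the estimate in this assay is 10000 nM, with a range from 4500 nM to 22000 nM.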

Compound 4, half-maximal inhibitory concentration: 3460 nM
Beside the measured number, compound 4's estimate is 2.9-fold (0.46 log units) above it; the measured number lies below the stated range.
By their numbers in this assay, from the lowest: compounds 4, 1 and 2 (each within the scatter of the next); then compound 3.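

In this assay fluoro in place of hydrogen on an aromatic carbon, ortho to a large group and meta to a fluoro group, gives a 2.9-fold lower number from compound 3 to compound 4 (0.47 log units; beyond the scatter) and thus shows that a single added atom on this ring is enough to shift the number. The change also removes the gap that set compound 3 apart, with a 1.4-fold lower number from compound 2 to compound 4 (0.14 log units; within the scatter) and a 1.1-fold lower number from compound 1 to compound 4 (0.02 log units; within the scatter) leaving compound 3 alone at the high end of the four. No measurement is available that would explain this shift.

Chloro, methyl or methoxy at this place remain open, so it cannot be said whether the shift belongs to fluoro itself or would follow with another group. Also open, as far as these compounds go, is whether the same fluoro would shift the number on the rings of compound 1 and compound 2.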